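The compounds below may be only part of what the source reports. "The series", "measured", "known", "first", "only" and "open" are said of these compounds alone.

Working notes on the arylthio enone series.

Three compounds of the series have numbers in a functional assay on DU-145 cells (Homo sapiens) for inhibition, read by trypan blue exclusion, with a stated time of 96 h; on this read-out higher numbers stand for weaker inhibition of growth and lower numbers for stronger inhibition of growth. Compound 1 `COc1ccc(/C=C(/Sc2ccc(C)cc2)C(=O)c2ccc(Cl)cc2)cc1O` is the strongest of the three: in this assay compound 1 gives 1000 nM. Compound 2 `Cc1ccc(S/C(=C/c2ccc(Br)cc2)C(=O)c2ccc(Cl)cc2)cc1` gives 25000 nM, and compound 3 `COc1ccccc1/C=C(/Sc1ccc(C)cc1)C(=O)c1ccc(Cl)cc1` gives 25000 nM. Compound 3 stands level with compound 2 at the digits shown, the two together at the high end of the three numbers; the step of no change at the digits printed from compound 2 to compound 3 (within the scatter) lies within the scatter, while the step of a 25-fold higher number from compound 1 to compound 3 (1.40 log units; beyond the scatter) is large, as is a 25-fold higher number from compound 1 to compound 2 (1.40 log units; beyond the scatter). Thus the 3-hydroxy-4-methoxyphenyl of compound 1 is the only variant so far that separates from the rest.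

The next compound, compound 4 `Cc1ccc(S/C(=C/c2cc(C)cc(C)c2)C(=O)c2ccc(Cl)cc2)cc1`, differs from compound 3 in one place: 3,5-dimethylphenyl in place of 2-methoxyphenyl on a double-bonded chain carbon bound to a double-bonded chain carbon. Among the measured compounds shown here, two measured steps bear on this. no change at the digits printed from compound 2 to compound 3 (within the scatter) shows that exchanging one group without hydroxy for another without hydroxy left the number unchanged, and a 25-fold higher number from compound 1 to compound 2 (1.40 log units; beyond the scatter) shows the large loss when the hydroxy-bearing group is removed. The entering 3,5-dimethylphenyl carries no hydroxy and no hydrogen-bond acceptor, so no step beyond the scatter is expected from compound 3 to compound 4; the expected step is no change at the digits printed from compound 3 to compound 4 (within the scatter). Compound 4 is therefore estimated at 25000 nM in this assay, with a range from 8000 nM to 80000 nM.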

Compound 4, concentration for 50% growth inhibition: 50000 nM
Compound 4: the middle estimate sits 2.0-fold (0.30 log units) below what was measured; the range from low to high includes it.
By their numbers in this assay, from the lowest: compound 1; then compounds 2, 3 and 4 (each within the scatter of the next).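

In this assay, a third group without hydroxy at this place, on a double-bonded chain carbon bound to a double-bonded chain carbon, behaves like the other two: a 2.0-fold higher number from compound 3 to compound 4 (0.30 log units; within the scatter) and a 2.0-fold higher number from compound 2 to compound 4 (0.30 log units; within the scatter) both stay inside the usual scatter, and 2-methoxyphenyl, 4-bromophenyl and 3,5-dimethylphenyl cannot be told apart here. The exchange from compound 3 to compound 4 gives up the hydrogen-bond acceptor of the 2-methoxyphenyl without a step beyond the scatter, while a 50-fold higher number from compound 1 to compound 4 (1.70 log units; beyond the scatter) is large and leaves compound 1, with its 3-hydroxy-4-methoxyphenyl, apart from all three others. No measurement in hand offers an explanation for these numbers.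

Open, as far as these compounds go, is whether the hydroxy or the methoxy of the 3-hydroxy-4-methoxyphenyl carries the separation of compound 1, and whether an amine in place of that hydroxy would keep it. Also open, from the compounds shown here alone, is whether the same separation would hold with a carboxylic acid on this aryl group, or with changes elsewhere on the shared core.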